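A few compounds are considered here, and "the series" means these few. Any claim that something is new, unique, unknown or untested is made for them only; others in the source may bear on it.

In a functional assay on ECa-109 cells (Homo sapiens) for antiproliferative activity, read by MTT assay, with a stated time of 48 h (on this read-out higher numbers stand for weaker inhibition and lower numbers for stronger inhibition), compound 3 `Cn1cc(C2=C(c3nn(CCCN4CCCCC4)c4ncccc34)C(=O)NC2=O)c2ccccc21` gives 42300 nM as the higher of the two exact numbers, while compound 1 `Cn1cc(C2=C(c3nn(CCn4ccnc4)c4ncccc34)C(=O)N(c3ccccc3)C2=O)c2ccccc21` gives 8770 nM on the same read-out. Compound 2 `Cn1cc(C2=C(c3nn(CCCn4ccnc4)c4ncccc34)C(=O)NC2=O)c2ccccc21` gives > 100000 nM as a limit of the assay and not a number. Compound 4 `Cn1cc(C2=C(c3nn(CCn4ccnc4)c4ncccc34)C(=O)NC2=O)c2ccccc21` differs from compound 3 by one change (1H-imidazol-1-yl in place of (piperidin-1-yl)methyl on a saturated chain carbon, two bonds along the chain from an aromatic nitrogen): 1H-imidazol-1-yl in place of (piperidin-1-yl)methyl on a saturated chain carbon, two bonds along the chain from an aromatic nitrogen. Going by the values given here, the one measured step that bears on it (an at least 2.3-fold lower number from compound 2 to compound 3 (0.37 log units; beyond the scatter)) made the opposite swap on the longer chain, so a modest rise in the number is expected rather than a fall. The expected step is a 2.1-fold higher number from compound 3 to compound 4 (0.33 log units; beyond the scatter) on this estimate. Compound 4 is estimated at 90000 nM (30000 nM to 250000 nM).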

Compound 4, half-maximal inhibitory concentration: > 100000 nM
Compound 4: only a limit was reported; the forecaster's own chance of this, stated with the estimate: 40%; at least 1.1-fold (0.04 log units) between middle value and limit.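

In this assay, the change from 3-(piperidin-1-yl)propyl to 2-(1H-imidazol-1-yl)ethyl gives an at least 2.3-fold higher number from compound 3 to compound 4 (0.37 log units; beyond the scatter). Hydrogen in place of phenyl on the amide-type nitrogen gives an at least 11-fold higher number from compound 1 to compound 4 (1.05 log units; beyond the scatter), the largest readable step in this set, so among these compounds the phenyl goes with the lowest number.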